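Halogenated Aryl Substituent Returns to the Fused Core

The source may report more compounds than this note shows. Statements on the series, on what has been measured and on what is new or still open speak of the compounds shown alone.

Three compounds sharing one core have been measured in an assay for binding affinity to dual specificity mitogen-activated protein kinase kinase 4 (Homo sapiens), read by KINOMEscan, tested at 100 nM; a higher number here means a weaker effect of the compound at the concentration tested, a lower number a stronger effect:

Compound 1, `CCCS(=O)(=O)Nc1ccc(F)c(C(=O)c2n[nH]c3ncc(-c4cccc(Cl)c4)cc23)c1F`, gives 40%.
Compound 2, `CCCS(=O)(=O)Nc1ccc(F)c(C(=O)c2n[nH]c3ncc(-c4ccc(Cl)c(Cl)c4)cc23)c1F`, gives 45%.
Compound 3, `CCCS(=O)(=O)Nc1ccc(F)c(C(=O)c2n[nH]c3ncc(-c4ccc(C)c(C)c4)cc23)c1F`, gives 20%.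

Compound 3 stands lowest of the three numbers. Its nearest neighbour is compound 1, with a number 20 percentage points lower from compound 1 to compound 3 (beyond the scatter), and its furthest is compound 2, with a number 25 percentage points lower from compound 2 to compound 3 (beyond the scatter). Between the two chlorinated compounds themselves the step is small, a number 5 percentage points higher from compound 1 to compound 2 (within the scatter).

Compound 4, `CCCS(=O)(=O)Nc1ccc(F)c(C(=O)c2n[nH]c3ncc(-c4ccc(Cl)c(C(F)(F)F)c4)cc23)c1F`, is not yet measured. Its change from compound 3 is 4-chloro-3-(trifluoromethyl)phenyl in place of 3,4-dimethylphenyl on an aromatic carbon. Within the data shown here, the step that bears most directly on this change is the one from compound 2 to compound 3, where a dichlorinated aryl was exchanged for the dimethyl aryl and the number fell; compound 4 reverses that direction by bringing back a chloro together with a trifluoromethyl. The step from compound 1 to compound 2 shows that adding a chloro on this aryl changed little. Compound 4 is therefore expected to move back toward the level of compound 2, an expected step of a number 22 percentage points higher from compound 3 to compound 4 (beyond the scatter) in this assay. The estimated value for compound 4 is 42%, with a range from 22% to 68%.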

Compound 4, a percentage reported as activity, at one concentration (the size of the read-out at that concentration, not a potency): 15%
Estimate against measurement, compound 4: 27 percentage points above; measured number outside the range, below it.
By their numbers in this assay, from the lowest: compounds 4 and 3 (each within the scatter of the next); then compounds 1 and 2 (each within the scatter of the next).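

In this assay, the step of a number 5 percentage points lower from compound 3 to compound 4 (within the scatter) places a halogen-bearing aryl at this position level with the dimethyl one, so carrying a chloro does not by itself tie this aryl to the higher numbers of the two chlorinated compounds. Among these compounds, the single change of trifluoromethyl in place of chloro gives a number 30 percentage points lower from compound 2 to compound 4 (beyond the scatter), and the comparison with the 3-chlorophenyl compound gives a number 25 percentage points lower from compound 1 to compound 4 (beyond the scatter), so compound 4 keeps a chloro yet separates clearly from both earlier chlorinated compounds. Nothing in the data given accounts for this separation.

The compounds shown leave open whether the trifluoromethyl group would give the same reading on this aryl without the chloro, or whether the two groups act only as a pair. They also leave open whether a group of a different kind at this place, such as an amine or a carboxylic acid, would read with compounds 3 and 4 or with compounds 1 and 2, and a reading at one concentration gives no potency for any of them.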